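Ethoxyethyl in place of carboxybenzyl on the benzimidazole nitrogen

The source may hold more compounds than are shown below. What is called first, only, known or untested is meant among the compounds shown, and "the series" means these compounds.

Measured so far:
Compound 1 `CCOCCn1c(C(=O)C2CCN(CCC3(c4ccc(Cl)c(Cl)c4)CCN(C(=O)c4cc(OC)c(OC)c(OC)c4)C3)CC2)nc2ccccc21`: 7.51 nM
Compound 2 `COc1ccc(C2(CCN3CCC(C(=O)c4nc5ccccc5n4Cc4ccc(C(=O)O)cc4)CC3)CCN(C(=O)c3cc(OC)c(OC)c(OC)c3)C2)cc1OC`: 7 nM

In a functional assay for antagonist activity at Substance-P receptor (Cavia porcellus) (a higher number here means a weaker inhibitor, a lower number a stronger inhibitor), compound 2 gives 7 nM, and in this assay compound 1 gives 7.51 nM; the two numbers lie within the usual scatter of each other, so no order between them can be read. Compound 1 and compound 2 differ in more than one place, and their values simply show that both sit in the same range.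

Compound 3 `CCOCCn1c(C(=O)C2CCN(CCC3(c4ccc(OC)c(OC)c4)CCN(C(=O)c4cc(OC)c(OC)c(OC)c4)C3)CC2)nc2ccccc21` differs from compound 2 by ethoxymethyl in place of 4-carboxyphenyl on a saturated chain carbon bound to an aromatic nitrogen. For the measured compounds named here, the group that enters is the one carried by compound 1, so compound 3 combines pieces already present in both measured compounds, each of which lands near the same value.

Going by the values given here, no step between measured compounds is on hand for this change. The expected step is no change at the digits printed from compound 2 to compound 3 (within the scatter), none beyond the scatter. Compound 3 is therefore expected at 7 nM, with a range from 3 nM to 18 nM.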

Compound 3, half-maximal inhibitory concentration: 7.39 nM
The estimate for compound 3 lay 1.1-fold (0.02 log units) below the measured number; the range from low to high includes it.
By their numbers in this assay, from the lowest: compounds 2, 3 and 1 (each within the scatter of the next).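

In this assay, ethoxymethyl in place of 4-carboxyphenyl on a saturated chain carbon bound to an aromatic nitrogen gives a 1.1-fold higher number from compound 2 to compound 3 (0.02 log units; within the scatter), so at this place the series carries either the 4-carboxybenzyl or the 2-ethoxyethyl group with no readable change in the number. On a saturated ring carbon, 3,4-dimethoxyphenyl in place of 3,4-dichlorophenyl gives a 1.0-fold lower number from compound 1 to compound 3 (0.01 log units; within the scatter), so compound 3 separates the two differences between compound 1 and compound 2, and neither moves the number beyond the scatter on its own. No measurement on hand gives a reason for this flatness.

From the compounds shown here alone, whether an amine or a much longer chain at the nitrogen-bound position would keep the number in this range stays open. So does whether a phenyl ring without chlorine or methoxy groups would do so on the saturated ring carbon.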